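This account rests on a few compounds, and the source may have more. Where it says the series, first, only, none or still open, it means among the compounds named here.

Compound 1 `CN(C)C(=O)CCNC(=O)c1cc(-c2ccc(F)cc2)no1` is one of two compounds tested in an ADME assay on microsomes from liver (Homo sapiens) for metabolic stability, with a stated time of 0.5 h, tested at 0.5 mg/mL (on this read-out lower numbers stand for a less stable compound and higher numbers for a more stable compound), where compound 1 gives 87%. Compound 2 `CC(CC(=O)N(C)C)NC(=O)c1cc(-c2ccc(F)cc2)no1` differs from it by a methyl in place of hydrogen on a saturated chain carbon, and in this assay compound 2 gives 91%. Within the data shown here, the only measured step, a number 4 percentage points higher from compound 1 to compound 2 (within the scatter), changes the chain and stays within the scatter, so on these numbers compound 1 and compound 2 stand on the same footing.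

Compound 3 `CN(C)C(=O)CCNC(=O)c1cc(-c2ccccc2)no1` differs from compound 1 at the ring instead: hydrogen in place of fluoro on an aromatic carbon, that is, 4-fluorophenyl becomes phenyl. Among the measured compounds shown here, no measured step touches this part of the shared core, so the expectation rests only on how little the one known step moved. The expected step of a number 5 percentage points lower from compound 1 to compound 3 (within the scatter) is therefore small, likely none beyond the scatter. Compound 3 is estimated at 82%, within a range of 65% to 95%.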

Compound 3, percent of the compound remaining: 81%
Compound 3: middle estimate off by 1 percentage points, on the high side; measured number inside the range.
By their numbers in this assay, from the lowest: compounds 3, 1 and 2 (each within the scatter of the next).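

In this assay, among these compounds, the change from 4-fluorophenyl to phenyl gives a number 6 percentage points lower from compound 1 to compound 3 (within the scatter) and so is the first measured step at the aromatic end of the shared core, away from the chain. On these numbers, compound 3 and compound 1 stand on the same footing, so hydrogen and fluoro on this aromatic carbon, para to a large group, cannot be told apart in this read-out. No supporting evidence bears on what lies behind this result.

Still open, on these data alone, is whether another group on this aromatic carbon, such as chloro, methoxy, trifluoromethyl or an amine, would give a step beyond the scatter. Also open, as far as these compounds go, is whether the chain methyl of compound 2 and the phenyl of compound 3, joined in one compound, would stay within the scatter of compound 1.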